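Bromo Added to a Compound With One Small Measured Step

This account rests on a few compounds, and the source may have more. Where it says the series, first, only, none or still open, it means among the compounds named here.

Measured in a functional assay on HeLa cells (Homo sapiens) for antiproliferative activity, read by sulforhodamine B assay, with a stated time of 48 h; on this read-out higher numbers stand for weaker inhibition and lower numbers for stronger inhibition
compound 1 `COc1ccc2nc(-c3ccc(N/C=C\C(=O)c4cc(OC)c(OC)c(OC)c4)cc3)sc2c1` gives 14100 nM
compound 2 `COc1ccc2nc(-c3ccc(N/C=C\C(=O)c4cc(OC)c(OC)c([N+](=O)[O-])c4)cc3)sc2c1` gives 16100 nM

For the measured compounds named here, compound 1 sits level with compound 2, its only measured neighbour. Going by the values given here, the one measured step, nitro in place of methoxy on an aromatic carbon, is a 1.1-fold higher number from compound 1 to compound 2 (0.06 log units; within the scatter) and so shows no real change. Compound 3 `COc1ccc2nc(-c3ccc(N/C=C\C(=O)c4cc(OC)c(OC)c(OC)c4Br)cc3)sc2c1` differs from compound 1 by bromo in place of hydrogen on an aromatic carbon and this replaces a hydrogen rather than a methoxy group, so that step is only a thin guide. The expected size is a 1.2-fold lower number from compound 1 to compound 3 (0.07 log units; within the scatter) with no shift beyond the scatter expected in this assay here. Compound 3 is estimated at 12000 nM with an expected range from 4000 nM to 35000 nM overall.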

Compound 3, half-maximal inhibitory concentration: 8020 nM
Compound 3: the middle estimate sits 1.5-fold (0.18 log units) above what was measured; measured number inside the range.
By their numbers in this assay, from the lowest: compounds 3, 1 and 2 (each within the scatter of the next).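

Bromo in place of hydrogen on this aromatic carbon, ortho to a large group, gives a 1.8-fold lower number from compound 1 to compound 3 (0.25 log units; within the scatter) in this assay. The earlier step swapped one group for another at a different place on the ring, whereas this one shows that a hydrogen here can give way to a single bromine atom with no change beyond the scatter. No measurement available here accounts for this result. Going by these compounds, whether a different group at this position, such as an amine or a carboxylic acid, would shift the number beyond the scatter remains open.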